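The source may report more compounds than this note shows. Statements on the series, on what has been measured and on what is new or still open speak of the compounds shown alone.

Measured compounds:
compound 1 `CCCn1ccc2cc(N3CCC(O)CC3)cc(Cl)c2c1=O`: 106%
compound 2 `CCCn1ccc2cc(-c3cncnc3)cc(Cl)c2c1=O`: 28%

In a functional assay on CHO cells for agonist activity at metabotropic glutamate receptor 2 (Homo sapiens), read by GTPgammaS binding (a lower number here means a smaller maximal response, a higher number a larger maximal response), compound 1 gives 106%, whereas compound 2 gives 28%. Going by the values given here, compound 2 therefore stands lowest of the two numbers, the only other compound being compound 1, which lies higher by a number 78 percentage points lower from compound 1 to compound 2 (beyond the scatter). That single step, replacing a 4-hydroxypiperidin-1-yl with a pyrimidin-5-yl, is the only one recorded and is large.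

Compound 3 `CCCn1ccc2cc(-c3cn[nH]c3)cc(Cl)c2c1=O` differs from compound 2 by 1H-pyrazol-4-yl in place of pyrimidin-5-yl on an aromatic carbon. Among the compounds with values here, the one measured step exchanges a saturated ring for an aromatic one, while the step to compound 3 exchanges one aromatic ring for another; no measured pair shows that kind of change, so its bearing is indirect. Given the drop seen in a number 78 percentage points lower from compound 1 to compound 2 (beyond the scatter) after the pyrimidin-5-yl entered, compound 3 is expected to stay in the lower region rather than return toward compound 1, with a step of a number 12 percentage points higher from compound 2 to compound 3 (beyond the scatter) that may fall within the scatter. The estimate for compound 3 in this assay is 40%, with a range from 15% to 75%.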

Compound 3, largest response reached (Emax), in percent of the reference or control that the assay uses: 65%
For compound 3 the middle estimate is 25 percentage points below the measured one, and the stated range covers the measured number.
By their numbers in this assay, from the lowest: compound 2; then compound 3; then compound 1.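

In this assay, this position on the aromatic carbon, meta to the chloro group, proves sensitive to more than the loss of a saturated ring, since exchanging one aromatic ring for another gives a number 37 percentage points higher from compound 2 to compound 3 (beyond the scatter). An aromatic ring here therefore does not fix the response at the level of compound 2, yet the 1H-pyrazol-4-yl group does not restore the level of the 4-hydroxypiperidin-1-yl group either, the remaining step being a number 41 percentage points lower from compound 1 to compound 3 (beyond the scatter). The exchange replaces a six-membered aromatic ring with a five-membered one and brings in a hydrogen-bond donor that pyrimidin-5-yl lacks, but nothing available says which of these differences accounts for the rise.

The compounds shown leave open whether the hydrogen on the pyrazole nitrogen matters, a question that 1-methyl-1H-pyrazol-4-yl, with a methyl group on that nitrogen, could separate from the change in ring size. From the compounds shown here alone, it also remains open whether the hydroxyl of compound 1 contributes to its response, which plain piperidin-1-yl or morpholin-4-yl at the same place could test.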